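The source may report more compounds than this note shows. Statements on the series, on what has been measured and on what is new or still open speak of the compounds shown alone.

Compound 1 `COc1cc(C(=O)c2cn(-c3ccccc3[N+](=O)[O-])cc2-c2ccccc2)cc(OC)c1OC` and compound 2 `COc1cc(C(=O)c2cn(-c3ccccc3N)cc2-c2ccccc2)cc(OC)c1OC` share one core and differ by amino in place of nitro on an aromatic carbon. In a functional assay on MCF7 cells (Homo sapiens) for cytotoxicity, read by MTT assay, with a stated time of 96 h (a lower number here means a stronger inhibitor, a higher number a weaker inhibitor), compound 1 gives 5000 nM, and compound 2 gives 3800 nM, so this change made a 1.3-fold lower number from compound 1 to compound 2 (0.12 log units; within the scatter). Compound 3 `COc1cc(C(=O)c2cn(-c3ccc([N+](=O)[O-])cc3)cc2-c2ccccc2)cc(OC)c1OC` is built on a different core, which differs from the core of compound 1 by 4-nitrophenyl in place of 2-nitrophenyl on an aromatic nitrogen. In this assay compound 3 gives 4000 nM. Compound 4 `COc1cc(C(=O)c2cn(-c3ccc(N)cc3)cc2-c2ccccc2)cc(OC)c1OC` has not yet been measured and differs from compound 3 by amino in place of nitro on an aromatic carbon. Within the data shown here, this is the same kind of change as the one between compound 1 and compound 2, though the surroundings differ: there the group sits ortho to a large group, here it sits para to a large group. Because the earlier instance gave a 1.3-fold lower number from compound 1 to compound 2 (0.12 log units; within the scatter), the expected step for compound 4 is a 1.3-fold lower number from compound 3 to compound 4 (0.12 log units; within the scatter). For compound 4 the estimated value in this assay is 3000 nM, likely between 1200 nM and 8000 nM.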

Compound 4, half-maximal inhibitory concentration: 35 nM
Beside the measured number, compound 4's estimate is 86-fold (1.93 log units) above it; the whole stated range lies above it.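

In this assay, the swap of nitro for amino does not carry over from one core to the other with a step of similar size: the same change on two cores in this assay, a 1.3-fold lower number (0.12 log units; within the scatter) from compound 1 to compound 2 and a 110-fold lower number (2.06 log units; beyond the scatter) from compound 3 to compound 4, 87-fold (1.94 log units) apart, beyond the scatter of two such steps. Compound 4 stands well apart from all three other compounds, with a 110-fold lower number from compound 3 to compound 4 (2.06 log units; beyond the scatter) and a 110-fold lower number from compound 2 to compound 4 (2.04 log units; beyond the scatter) and a 140-fold lower number from compound 1 to compound 4 (2.15 log units; beyond the scatter) as its steps, so the large step appears only where amino sits on the 4-aminophenyl group. Two cores show that the step can depend on its surroundings, but they do not show why, or what a further core would give.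

Going by these compounds, whether a hydroxyl or a dimethylamino group in the same place would match amino remains open. So does whether compound 4 stands out in other cell lines.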